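Oxime in Place of Amine on a Tellurium-Bearing Aryl Core

The compounds below may be only part of what the source reports. "The series", "measured", "known", "first", "only" and "open" are said of these compounds alone.

Compound 1 `C/C(=N\O)c1ccc([Te]CCCO)cc1`: 13.1 ug/mL
Compound 2 `C=CCNC(C)c1ccc([Te]CCCC)cc1`: measured
Compound 3 `CCCC[Te]c1cccc(C(C)N)c1`: 19.2 ug/mL

In a functional assay, read by spectrophotometry, with a stated time of 30 min (on this read-out lower numbers stand for stronger inhibition and higher numbers for weaker inhibition), compound 2 gives only a limit, > 100 ug/mL. Among the two numbers obtained, compound 3 has the higher one, yet it lies within the scatter of the number for compound 1, so the two cannot be told apart. Compound 4 `CCCC[Te]c1cccc(/C(C)=N/O)c1` differs from compound 3 by a group of 4 heavy atoms (2 carbon, 1 nitrogen, 1 oxygen; no ring) in place of a group of 3 heavy atoms (2 carbon, 1 nitrogen; no ring), on an aromatic carbon. Among the measured compounds shown here, no step between measured compounds is available for comparison. Compound 1 carries a related group on its own core and gives 13.1 ug/mL, so for compound 4 a step of a 1.4-fold lower number from compound 3 to compound 4 (0.14 log units; within the scatter) is expected, not beyond the scatter. Compound 4 is estimated at 14 ug/mL, with a range from 6 ug/mL to 35 ug/mL.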

Compound 4, half-maximal inhibitory concentration: 5.12 ug/mL
Beside the measured number, compound 4's estimate is 2.7-fold (0.44 log units) above it, outside the stated range (below it).
By their numbers in this assay, from the lowest: compound 4; then compounds 1 and 3 (each within the scatter of the next). At a limit, above all of these: compound 2.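

In this assay, putting the oxime in place of 1-aminoethyl on this aromatic carbon gives a 3.8-fold lower number from compound 3 to compound 4 (0.57 log units; beyond the scatter). Among the compounds shown here, this is the first comparison of compounds that differ in one place, and it shows that this single change moves the number beyond the scatter. Nothing measured here bears on why the step occurs.

From the compounds shown here alone, whether a ketone, a carboxylic acid or a longer chain in place of the oxime would give a lower number stays open. So does whether the same change would give a similar step on another aromatic carbon.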